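Dimethylamino in place of amino on a carbonyl carbon

The compounds below may be only part of what the source reports. "The series", "measured", "known", "first", "only" and "open" are said of these compounds alone.

In a functional assay on U-87MG ATCC cells (Homo sapiens) for cytotoxicity, with a stated time of 7 days (on this read-out lower numbers stand for stronger inhibition and higher numbers for weaker inhibition), compound 3 `CC(C)=CCC/C(C)=C/CC/C(C)=C/CSc1ccccc1C(N)=O` gives 10000 nM, and compound 2 `COC(=O)c1ccccc1SC/C=C(\C)CC/C=C(\C)CCC=C(C)C` gives 10000 nM. These two share the lowest number of the three, while compound 1 `CC(C)=CCC/C(C)=C/CC/C(C)=C/CSc1ccccc1C(=O)OC(C)C` gives 52000 nM.

Compound 4 `CC(C)=CCC/C(C)=C/CC/C(C)=C/CSc1ccccc1C(=O)N(C)C` has not yet been measured in this assay. It differs from compound 3 by one change, dimethylamino in place of amino on a carbonyl carbon.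

For the measured compounds named here, three measured steps bear on this change, all at the same carbonyl carbon. Methyl in place of isopropyl on the oxygen gave a 5.2-fold lower number from compound 1 to compound 2 (0.72 log units; beyond the scatter), and amino in place of isopropoxy gave a 5.2-fold lower number from compound 1 to compound 3 (0.72 log units; beyond the scatter). Amino in place of methoxy gave no change at the digits printed from compound 2 to compound 3 (within the scatter). Among these three compounds, then, the isopropoxy group of compound 1 goes with the highest number, at 52000 nM, while the methoxy and amino groups show no difference. None of the three carries a substituted nitrogen on the carbonyl, so the evidence is indirect. By analogy with the steps from compound 1, a modest rise in the number is expected, smaller than those steps and possibly close to the scatter. The expected step is a 1.8-fold higher number from compound 3 to compound 4 (0.26 log units; within the scatter). For compound 4 the estimated value is 18000 nM, with an expected range from 7000 nM to 50000 nM.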

Compound 4, half-maximal inhibitory concentration: 20000 nM
For compound 4 the middle estimate is 1.1-fold (0.05 log units) below the measured one; the range from low to high includes it.
By their numbers in this assay, from the lowest: compounds 2, 3 and 4 (each within the scatter of the next); then compound 1.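

In this assay, dimethylamino in place of amino on the carbonyl carbon gives a 2.0-fold higher number from compound 3 to compound 4 (0.30 log units; within the scatter), so this first substituted nitrogen at the position, which lacks the hydrogen-bond donor counted for amino, produces no step beyond the scatter. Set against the two esters, dimethylamino gives a 2.0-fold higher number from compound 2 to compound 4 (0.30 log units; within the scatter) and a 2.6-fold lower number from compound 1 to compound 4 (0.41 log units; beyond the scatter), which leaves compound 2, compound 3 and compound 4 together, with compound 1 and its isopropoxy group alone apart from them. The compounds shown offer no measurement that explains why these groups sit where they do.

Going by these compounds, what a methylamino group would give stays open, and it could show whether one methyl on the nitrogen behaves like amino or like dimethylamino. Also open, on these data alone, is whether a carboxylic acid, a diethylamino group or a longer chain on the nitrogen at this carbonyl carbon would stay with compound 2, compound 3 and compound 4 or move toward compound 1, since the four compounds cover only a narrow set of groups at this place.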